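A few compounds are considered here, and "the series" means these few. Any claim that something is new, unique, unknown or untested is made for them only; others in the source may bear on it.

Measured compounds in the series so far:

compound 1 `O=C1COc2ccc(NC(=O)C3CCN(c4cccc(Cl)c4)CC3)cc2N1` — 190 nM
compound 2 `O=C(Nc1cnc2ccccc2c1)C1CCN(c2cccc(C(F)(F)F)c2)CC1` — 600 nM
compound 3 `Cc1cccc(N2CCC(C(=O)Nc3ccc4c(c3)NC(=O)CO4)CC2)c1` — 490 nM

All three values come from a functional assay for antagonist activity at transient receptor potential cation channel subfamily V member 1 (Homo sapiens), read by FLIPR and calcium flux; a higher number here means a weaker inhibitor, a lower number a stronger inhibitor. Compound 3 gives the second highest of the three numbers. Its nearest neighbour is compound 2, which in this assay gives 600 nM, a gap within the scatter, so the two cannot be ordered. Among the measured compounds shown here, its furthest neighbour is compound 1, which gives 190 nM; the one step on the same aryl ring, a 2.6-fold higher number from compound 1 to compound 3 (0.41 log units; beyond the scatter), is modest but beyond the scatter.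

Compound 4 `CC(C)c1ccccc1N1CCC(C(=O)Nc2ccc3c(c2)NC(=O)CO3)CC1` has not yet been measured. It differs from compound 3 in one place: 2-isopropylphenyl in place of 3-methylphenyl on an amine nitrogen in a ring.

For the measured compounds named here, only the step from compound 1 to compound 3 bears on this change, and it concerns a different substituent at a different point on that aryl ring; no measured pair covers an isopropyl group or the 2-position, and compound 2 carries a different core, so its value is used only as a point of reference. The measured step on this ring was modest, so a step of similar size is the expected scale, with no firm direction; the working expectation leans toward a slightly higher number, giving an estimated 1.4-fold higher number from compound 3 to compound 4 (0.15 log units; within the scatter). For compound 4 the estimate is 700 nM, with a range from 250 nM to 2500 nM.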

Compound 4, half-maximal inhibitory concentration: 180 nM
Compound 4: middle estimate off by 3.9-fold (0.59 log units), on the high side, and the stated range ends above it.
By their numbers in this assay, from the lowest: compounds 4 and 1 (each within the scatter of the next); then compounds 3 and 2 (each within the scatter of the next).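

In this assay, the ring amine nitrogen carries 2-isopropylphenyl with a gain over 3-methylphenyl (a 2.7-fold lower number from compound 3 to compound 4 (0.43 log units; beyond the scatter)), so a carbon-only aryl group with more heavy atoms is tolerated here and does not go with a higher number. Against 3-chlorophenyl the same group gives no readable difference (a 1.1-fold lower number from compound 1 to compound 4 (0.02 log units; within the scatter)), which means the chloro substituent of compound 1 is not required for a value at this level, and compounds 1 and 4 cannot be ordered. Nothing available explains either step.

Among the compounds shown here, whether the step from 3-methylphenyl belongs to the isopropyl group or to its place on the aryl ring stays open, since both change at once and no measured pair separates them. Also open, from the compounds shown here alone, is how a methoxy group, a nitrile or a small amine on that ring would read against these values, and whether 2-isopropylphenyl gives a similar result on the core of compound 2.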